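Methylating the Ring Hydroxyl in a Lactone Series

The source may report more compounds than this note shows. Statements on the series, on what has been measured and on what is new or still open speak of the compounds shown alone.

Compound 1 `O=C1C[C@H]2O[C@H]([C@H](O)c3ccccc3)[C@H](O)[C@H]2O1` carries two free hydroxy groups. In a functional assay on K562 cells (Homo sapiens) for inhibition, read by MTT assay, with a stated time of 72 h (on this read-out lower numbers stand for stronger inhibition and higher numbers for weaker inhibition), compound 1 gives 410 nM. Compound 3 `CO[C@@H]1[C@H]2OC(=O)C[C@H]2O[C@@H]1[C@H](O)c1ccccc1` differs from it by methyl in place of hydrogen on an oxygen on a saturated carbon, and this change gave a 13-fold higher number from compound 1 to compound 3 (1.12 log units; beyond the scatter). Compound 2 `CO[C@@H](c1ccccc1)[C@H]1O[C@@H]2CC(=O)O[C@@H]2[C@H]1O` has the methyl on the other oxygen instead; the difference between the cores of compound 1 and compound 2 is not broken down here. In this assay compound 2 gives 11500 nM and compound 3 gives 5360 nM. Compound 4 `CO[C@@H]1[C@H]2OC(=O)C[C@H]2O[C@@H]1[C@@H](OC)c1ccccc1` differs from compound 2 by methyl in place of hydrogen on an oxygen on a saturated carbon, the same change already seen from compound 1 to compound 3. A step of a 4.3-fold higher number from compound 2 to compound 4 (0.64 log units; beyond the scatter) is expected, weaker than before because compound 2 already sits high and the earlier step was a 13-fold higher number from compound 1 to compound 3 (1.12 log units; beyond the scatter). Compound 4 is therefore estimated at 50000 nM, within 15000 nM and 160000 nM.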

Compound 4, half-maximal inhibitory concentration: 9240 nM
The estimate for compound 4 lay 5.4-fold (0.73 log units) above the measured number; the measured number lies below the stated range.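

Where the other oxygen already carries a methyl, the same swap of hydroxy to methoxy gives a 1.2-fold lower number from compound 2 to compound 4 (0.10 log units; within the scatter), so in this assay it has no readable effect on this core. The change therefore does not carry over at one size from one core to another in this series: the same change on two cores in this assay, a 13-fold higher number (1.12 log units; beyond the scatter) from compound 1 to compound 3 and a 1.2-fold lower number (0.10 log units; within the scatter) from compound 2 to compound 4, 16-fold (1.21 log units) apart, beyond the scatter of two such steps

These two pairs show that the result of the change depends on the core it is made on, but they do not show why, and they cannot predict its size on any further core. The compounds shown leave open how an ethyl group or a longer chain on this oxygen would behave. They also leave open what an amine in place of the hydroxy group would do.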